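The source may report more compounds than this note shows. Statements on the series, on what has been measured and on what is new or still open speak of the compounds shown alone.

In a functional assay on MDA-MB-231 cells (Homo sapiens) for antiproliferative activity, read by WST assay, with a stated time of 72 h (a lower number here means a stronger inhibitor of growth, a higher number a weaker inhibitor of growth), compound 1 (`C#Cc1cccc(N/N=N/c2ccc(C(=N)N)cc2)c1`) gives 20500 nM while compound 2 (`N=C(N)c1ccc(/N=N/Nc2cccc(C#Cc3ccccn3)c2)cc1`) gives 14400 nM and compound 3 (`C#Cc1ccc(N/N=N/c2ccc(C(=N)N)cc2)cc1`) gives 30200 nM on the same read-out. Among these three numbers, that of compound 3 lies higher than that of compound 2 by more than the scatter, whereas compound 2 and compound 1 cannot be told apart.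

The change followed here leads from compound 2 to compound 4 (`N=C(N)c1ccc(/N=N/Nc2cccc(C#Cc3ccccc3)c2)cc1`), with phenyl in place of pyridin-2-yl on a triple-bonded carbon. Going by the values given here, no measured compound shows directly what this exchange does. The nearest evidence is a single step, which put pyridin-2-yl in place of hydrogen on a triple-bonded carbon (a 1.4-fold lower number from compound 1 to compound 2 (0.15 log units; within the scatter)). Resting on that small step, no change beyond the scatter is expected in this assay and neither direction is favoured. The estimated change is a 1.0-fold lower number from compound 2 to compound 4 (0.01 log units; within the scatter) and would leave the two compounds indistinguishable. For compound 4 the expected value is 14000 nM with an estimated range from 7000 nM to 28000 nM in this measurement.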

Compound 4, concentration for 50% growth inhibition: 9500 nM
The estimate for compound 4 lay 1.5-fold (0.17 log units) above the measured number; measured number inside the range.
By their numbers in this assay, from the lowest: compounds 4, 2, 1 and 3 (each within the scatter of the next, the first and the last beyond it).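

In this assay, the exchange of pyridin-2-yl for phenyl on the triple-bonded carbon gives a 1.5-fold lower number from compound 2 to compound 4 (0.18 log units; within the scatter), so the ring nitrogen and its hydrogen-bond acceptor can be replaced by carbon at this position without a change that this read-out can resolve. Going by these compounds alone, the new compound also gives the first step at this position that passes the scatter: phenyl in place of hydrogen gives a 2.2-fold lower number from compound 1 to compound 4 (0.33 log units; beyond the scatter), whereas pyridin-2-yl in place of hydrogen gave a 1.4-fold lower number from compound 1 to compound 2 (0.15 log units; within the scatter), although the two aromatic rings themselves cannot be told apart, and the step from hydrogen remains modest. Nothing measured here accounts for this result.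

The compounds shown leave open whether an amine or a carboxylic acid on the phenyl ring, or a longer chain in place of the ring on the triple-bonded carbon, would move the number further in either direction. They also leave open whether phenyl in place of hydrogen on the triple-bonded carbon of compound 3 would give a step of similar size.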